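A few compounds are considered here, and "the series" means these few. Any claim that something is new, unique, unknown or untested is made for them only; others in the source may bear on it.

Compound 1, `COc1cc(-c2cc(C(=O)O)c3ccccc3n2)ccc1OCC(=O)Nc1ccccc1`, is measured in an ADME assay on HaCaT cells (Homo sapiens) for inhibition; a lower number here means a stronger inhibitor, a higher number a weaker inhibitor. In this assay compound 1 reaches only a limit, > 300000 nM, and so its place on the scale is known only as a bound, (the limit of > 300000 nM in this assay, at which 1 of the 2 values shown sits). Compound 2, `COc1cc(-c2cc(C(=O)O)c3ccccc3n2)ccc1OCC(=O)Nc1ccccc1C`, carries a methyl in place of hydrogen on an aromatic carbon and gives 230000 nM in this assay, a change an at least 1.3-fold lower number from compound 1 to compound 2 (0.11 log units; that floor lies within the scatter) that stays within the usual scatter.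

Compound 3, `COc1cc(-c2cc(C(=O)O)c3ccccc3n2)ccc1OCC(=O)Nc1cccc(Cl)c1`, differs from compound 1 by chloro in place of hydrogen on an aromatic carbon, a shift from phenyl to 3-chlorophenyl. Within the data shown here, the only measured step that bears on it is the one from compound 1 to compound 2, a small substituent on the same phenyl ring, and that step did not leave the scatter. The step is therefore expected to be an at least 1.2-fold lower number from compound 1 to compound 3 (0.07 log units; that floor lies within the scatter), with no movement beyond the scatter. Compound 3 is estimated at 250000 nM, in a range from 100000 nM to 600000 nM.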

Compound 3, half-maximal inhibitory concentration: 192000 nM
Beside the measured number, compound 3's estimate is 1.3-fold (0.11 log units) above it, and the stated range covers the measured number.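

In this assay, chloro in place of hydrogen on an aromatic carbon, meta to a large group, gives an at least 1.5-fold lower number from compound 1 to compound 3 (0.19 log units; that floor lies within the scatter), so a chloro substituent, like the methyl of compound 2, has not been shown to move the number beyond the scatter. Exchanging 2-methylphenyl for 3-chlorophenyl gives a 1.2-fold lower number from compound 2 to compound 3 (0.08 log units; within the scatter), so compound 2 and compound 3 cannot be ordered in this assay. The true size of any step from compound 1 stays unknown because compound 1 stands at a limit: the limit of > 300000 nM in this assay, at which 1 of the 3 values shown sits.

The compounds shown leave open whether any group on this phenyl ring can move the number beyond the scatter. An amine, a carboxylic acid or a longer chain in the place of the chloro might answer that, and so might a change elsewhere on the shared core.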